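Ethyl for Trifluoromethyl on the Imidazolyl Chalcone Core

The compounds below may be only part of what the source reports. "The series", "measured", "known", "first", "only" and "open" are said of these compounds alone.

Measured so far in an assay on isolated protein for inhibition of Amine oxidase [flavin-containing] B (Homo sapiens); a higher number here means a weaker inhibitor, a lower number a stronger inhibitor:
- compound 1, `CCOc1ccc(C(=O)/C=C/c2ccc(CC)cc2)cc1`: compound 1 gives 210 nM
- compound 2, `O=C(/C=C/c1ccc(F)cc1)c1ccc(-n2ccnc2)cc1`: compound 2 gives only a limit, > 10000 nM
- compound 3, `O=C(/C=C/c1ccc(C(F)(F)F)cc1)c1ccc(-n2ccnc2)cc1`: compound 3 gives only a limit, > 10000 nM

Compound 3 stands at a limit of the assay, not at a number. Among the measured compounds shown here, the one measured single-point step, a step that the two limits leave unreadable from compound 2 to compound 3, cannot be read in size because the limit of > 10000 nM in this assay, at which 2 of the 3 values shown sit, holds both of its ends. For the measured compounds named here, compound 1, which carries ethyl on the same side but a different group on its other ring, is the only compound here with a numerical value.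

The compound not yet measured is compound 4, `CCc1ccc(/C=C/C(=O)c2ccc(-n3ccnc3)cc2)cc1`. It differs from compound 3 in one place: ethyl in place of trifluoromethyl on an aromatic carbon.

Going by the values given here, no measured step tells what ethyl in place of trifluoromethyl does on this core. Compound 1 shows that ethyl is compatible with measurable inhibition when the other ring differs, while compound 2 and compound 3 both sit at the limit with the shared imidazolyl ring. The step that the limit leaves unreadable from compound 3 to compound 4 is therefore expected to be small or unreadable, with a fair chance that compound 4 again returns only a limit. Compound 4 is estimated at 15000 nM, in the range 3000 nM to 60000 nM.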

Compound 4, half-maximal inhibitory concentration: 320 nM
For compound 4 the middle estimate is 47-fold (1.67 log units) above the measured one; the measured number lies below the stated range.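

On the shared core, the group para to a large group separates a limit from a measurable value: in this assay, ethyl in place of trifluoromethyl gives an at least 31-fold lower number from compound 3 to compound 4 (1.49 log units; beyond the scatter), and ethyl in place of fluoro gives an at least 31-fold lower number from compound 2 to compound 4 (1.49 log units; beyond the scatter). These steps give only a minimum size because one end of each sits at a limit: the limit of > 10000 nM in this assay, at which 2 of the 4 values shown sit. With 1H-imidazol-1-yl in place of ethoxy, the comparison with the ethyl compound lacking that group gives a 1.5-fold higher number from compound 1 to compound 4 (0.18 log units; within the scatter), so 1H-imidazol-1-yl does not by itself hold this core at the limit.

The compounds shown leave open whether the effect belongs to ethyl alone or extends to methyl, a longer chain such as propyl, or an amine at this place. On these data alone, the step between fluoro and trifluoromethyl cannot be read, so how those two groups compare on this core remains unknown.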